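This account rests on a few compounds, and the source may have more. Where it says the series, first, only, none or still open, it means among the compounds named here.

The measured compounds:

Compound 1 `O=C1COc2ccc(-c3cccc(NS(=O)(=O)c4ccc(F)cc4)c3)cc2N1C1CC1` gives > 40000 nM in a functional assay on HCT-116 cells (Homo sapiens) for antiproliferative activity, read by MTT assay, with a stated time of 72 h; on this read-out higher numbers stand for weaker inhibition and lower numbers for stronger inhibition; this is a limit of the assay and not a number.
Compound 2 `O=C1COc2ccc(-c3cnc(Cl)c(NS(=O)(=O)c4ccc(F)cc4)c3)cc2N1c1ccc(F)cc1` gives 34200 nM in this assay.
Compound 3 `COc1ncc(-c2ccc3c(c2)NC(=O)CO3)cc1NS(=O)(=O)c1ccc(F)cc1` gives 24900 nM in this assay.

Compound 1 stands at the edge of what this assay can resolve: the limit of > 40000 nM in this assay, at which 1 of the 3 values shown sits. For the measured compounds named here, the two compounds that did return numbers, compound 2 and compound 3, lie within the scatter of one another, and neither of them differs from compound 1 in a single place, so no measured step exists to lean on.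

Compound 4 `O=C1COc2ccc(-c3cccc(NS(=O)(=O)c4ccc(F)cc4)c3)cc2N1c1ccc(Cl)cc1` differs from compound 1 in one place: 4-chlorophenyl in place of cyclopropyl on an amide-type nitrogen in a ring. Going by the values given here, with no measured pair showing this change alone, the expectation rests on the fact that every compound of this core so far has come out weak. The step expected is an at least 1.6-fold lower number from compound 1 to compound 4 (0.20 log units; that floor lies within the scatter), small or none beyond the scatter. Compound 4 is estimated at 25000 nM, between 7000 nM and 40000 nM, with a fair chance that this assay again reports only a limit.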

Compound 4, half-maximal inhibitory concentration: 23900 nM
For compound 4 the middle estimate is 1.0-fold (0.02 log units) above the measured one; the measured number falls inside the stated range.
By their numbers in this assay, from the lowest: compounds 4, 3 and 2 (each within the scatter of the next). At a limit, above all of these: compound 1.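

In this assay the move to 4-chlorophenyl on the amide-type nitrogen in a ring gives an at least 1.6-fold lower number from compound 1 to compound 4 (0.22 log units; that floor lies within the scatter) and is the first step shown that isolates this position. With 7 heavy atoms in place of the 3 of cyclopropyl, compound 4 returns a number, but the floor of the step does not establish a gain beyond the scatter. How large the step really is cannot be read, because compound 1 stands at a limit and not at a number: the limit of > 40000 nM in this assay, at which 1 of the 4 values shown sits.

On these data alone, what remains open is whether any group on this nitrogen moves the number clearly beyond the scatter, for instance a plain phenyl or a chain ending in an amine. It is also open whether the chlorine of compound 4 contributes anything of its own, since no pair shown isolates it.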